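Shortening the chain of compound 3

A few compounds are considered here, and "the series" means these few. Any claim that something is new, unique, unknown or untested is made for them only; others in the source may bear on it.

Going by the values given here, in a functional assay on MCF7 cells (Homo sapiens) for antiproliferative activity, read by MTT assay, with a stated time of 72 h (on this read-out higher numbers stand for weaker inhibition and lower numbers for stronger inhibition), compound 3 (`CCCCCCCCCCCCNC[C@@H]1OC[C@H](N)[C@@H]1O`) gives 1800 nM as its result, the lowest of the three numbers so far. Compound 1 (`CCCCCCCCCCNC[C@@H]1OC[C@H](N)[C@@H]1O`) gives 34200 nM in this assay and sits nearest to it. Compound 2 (`CCCCCCCCCNC[C@@H]1OC[C@H](N)[C@H]1O`) gives 60300 nM as the furthest result, and both gaps lie beyond the scatter.

Compound 4 (`CCCCCCCCCNC[C@@H]1OC[C@H](N)[C@@H]1O`) differs from compound 3 in one place: hydrogen in place of propyl on a saturated chain carbon, nine bonds along the chain from an amine nitrogen sums it up, hydrogen in place of propyl on a saturated chain carbon, nine bonds along the chain from an amine nitrogen.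

Among the compounds with values here, one measured step bears on this change. The step of a 19-fold lower number from compound 1 to compound 3 (1.28 log units; beyond the scatter) came with ethyl in place of hydrogen on the chain, and it is large. Compound 4 goes the opposite way and loses more of the chain, so a large move to a higher number is expected. This rests on a single step, so no trend is established. Compound 4 has a chain of the same length as compound 2 but a different spatial arrangement at one centre of the core, and compound 2 with 60300 nM offers a second rough guide.

The estimated change is a 33-fold higher number from compound 3 to compound 4 (1.52 log units; beyond the scatter) in the direction of weaker inhibition. For compound 4 the expected result is 60000 nM in this assay, with 30000 nM to 120000 nM as the estimated range.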

Compound 4, half-maximal inhibitory concentration: 12500 nM
Beside the measured number, compound 4's estimate is 4.8-fold (0.68 log units) above it, and the stated range ends above it.
By their numbers in this assay, from the lowest: compound 3; then compound 4; then compounds 1 and 2 (each within the scatter of the next).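

Trading propyl for hydrogen on a saturated chain carbon, nine bonds along the chain from an amine nitrogen, gives a 6.9-fold higher number from compound 3 to compound 4 (0.84 log units; beyond the scatter) in this assay, yet trading methyl for hydrogen at the same place runs the opposite way, with a 2.7-fold lower number from compound 1 to compound 4 (0.44 log units; beyond the scatter). The earlier step alone could be read as a longer chain always giving a lower number, but among these three chains the number does not move in one direction with length, and compound 4 goes against that simple reading. The core matters as well, since a 4.8-fold lower number from compound 2 to compound 4 (0.68 log units; beyond the scatter) is a real change that can be traced to a single stereocentre at a saturated ring carbon, drawn R in one compound and S in the other, because nothing else separates them: the fact that compounds 2 and 4 differ only in the configuration as drawn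

As far as these compounds go, whether a longer chain than that of compound 3 would lower the number further, or raise it again, remains open. Also open is whether the ring configuration of compound 2 would have a similar effect when paired with the chain of compound 3, since its effect is shown here on one chain only.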